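The compounds below may be only part of what the source reports. "The series", "measured", "known", "first", "only" and "open" are said of these compounds alone.

Compound 1, `CO[C@H]1CC[C@@H](CN2CC(=O)Nc3ncc(-c4ccc(C(C)(C)O)nc4)nc32)CC1`, is the weakest of the three compounds with a result in an ADME assay on S9 fraction (Rattus norvegicus) for metabolic stability, with a stated time of 60 min; a higher number here means that more of the compound is left, a lower number that less of the compound is left: compound 1 gives 39%. Compound 3, `COCCN1C(=O)CNc2ncc(-c3ccc(C(C)(C)O)nc3)nc21`, stands nearest to it, and in this assay compound 3 gives 89%, which lies beyond the scatter above compound 1. Compound 2, `CO[C@H]1CC[C@H](N2CC(=O)Nc3ncc(-c4ccc(C(C)(C)O)nc4)nc32)CC1`, stands furthest away; in this assay compound 2 gives 94%. Within the data shown here, the only step between measured compounds that differ in one place is the one between compound 1 and compound 2, where 4-methoxycyclohexyl replaces (4-methoxycyclohexyl)methyl on a nitrogen on an aromatic ring in a ring, and it is large: a number 55 percentage points higher from compound 1 to compound 2 (beyond the scatter).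

Compound 4, `CC(C)(O)c1ccc(-c2cnc3c(n2)N(CC2CCCCC2)CC(=O)N3)cn1`, differs from compound 1 in another way: hydrogen in place of methoxy on a saturated ring carbon. Among the measured compounds shown here, no measured step removes a methoxy from a saturated ring carbon, so the step from compound 1 to compound 2 does not bear on this change, and nothing among the measured compounds points to a direction. In this assay compound 4 is therefore expected to sit near compound 1, with a step of a number 3 percentage points higher from compound 1 to compound 4 (within the scatter) that could fall within the scatter. Compound 4 is estimated to give 42%, between 20% and 68%.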

Compound 4, percent of the compound remaining: 16%
For compound 4 the middle estimate is 26 percentage points above the measured one, and the stated range ends above it.
By their numbers in this assay, from the lowest: compound 4; then compound 1; then compounds 3 and 2 (each within the scatter of the next).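

Taking the methoxy off the saturated ring carbon is not a neutral change in this assay: the step is a number 23 percentage points lower from compound 1 to compound 4 (beyond the scatter), so within this one pair, hydrogen at that place, three ring bonds from the ring atom that bears a large group, leaves less of the compound than methoxy does. The comparison with the other methoxy-bearing compound is wider still, with cyclohexylmethyl in place of 4-methoxycyclohexyl on the nitrogen giving a number 78 percentage points lower from compound 2 to compound 4 (beyond the scatter), so across compounds 4, 1 and 2 the number in this assay moves both with the methoxy on the ring and with how the ring is attached to the nitrogen. Nothing available to this account says what lies behind either shift.

From the compounds shown here alone, whether the gain belongs to methoxy itself or would also come with a hydroxyl, a fluorine, an amine or a carboxylic acid on the same ring carbon remains open. Going by these compounds, it is also open whether the step would keep its size on a plain cyclohexyl group attached directly to the nitrogen, where the high number of compound 2 offers a different starting point.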